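Carbonate and ester chains on a shared phenol core

The source may hold more compounds than are shown below. What is called first, only, known or untested is meant among the compounds shown, and "the series" means these compounds.

Measured so far in an ADME assay on L929 cells (Mus musculus) for cytotoxicity, read by MTT assay, with a stated time of 24 h; a higher number here means that more compound is needed for the effect, a lower number that less compound is needed:
Compound 1, `COCCOCCOCCOCC(=O)Oc1c(C(C)C)cccc1C(C)C`, gives 650000 nM.
Compound 2, `COCCOCCOCCOCCOCC(=O)Oc1c(C(C)C)cccc1C(C)C`, gives 440000 nM.
Compound 3, `COCCOCCOCCOC(=O)Oc1c(C(C)C)cccc1C(C)C`, gives 2290000 nM.

Compound 1 and compound 2 share one core, and compound 3 carries another; how the core of compound 3 differs from the core of compound 1 is not broken down here. Within the first pair the change is methoxymethyl in place of hydrogen on a saturated chain carbon bound to an oxygen on a saturated carbon, and the step it made was a 1.5-fold lower number from compound 1 to compound 2 (0.17 log units; within the scatter). Compound 3 stands apart from both: its number is higher than that of compound 1 and that of compound 2, and both gaps lie beyond the usual scatter.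

Compound 4, `COCCOCCOCCOCCOC(=O)Oc1c(C(C)C)cccc1C(C)C`, has not yet been measured in this assay. Among the compounds with values here, it differs from compound 3 by methoxymethyl in place of hydrogen on a saturated chain carbon bound to an oxygen on a saturated carbon, which is the same change, at the same place, as the one from compound 1 to compound 2. On that footing the step from compound 3 to compound 4 is expected to be small, about a 1.4-fold lower number from compound 3 to compound 4 (0.16 log units; within the scatter), because the earlier instance gave a 1.5-fold lower number from compound 1 to compound 2 (0.17 log units; within the scatter). The estimate rests on a single earlier example of the change, made on a different core, so the range is kept wide. Compound 4 is therefore expected to give about 1600000 nM in this assay, with a plausible span from 800000 nM to 3500000 nM.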

Compound 4, half-maximal effective concentration: 1390000 nM
For compound 4 the middle estimate is 1.2-fold (0.06 log units) above the measured one; the measured number falls inside the stated range.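

In this assay, placing methoxymethyl in place of hydrogen on a saturated chain carbon bound to an oxygen on a saturated carbon gave a 1.6-fold lower number from compound 3 to compound 4 (0.22 log units; within the scatter). Set beside the earlier instance of the same change, on the other core, the new step agrees with it: the same change on two cores in this assay, a 1.5-fold lower number (0.17 log units; within the scatter) from compound 1 to compound 2 and a 1.6-fold lower number (0.22 log units; within the scatter) from compound 3 to compound 4, 1.1-fold (0.05 log units) apart, within the scatter of two such steps

For this series, that means the change carried from the core of compound 1 to the core of compound 3 with a similar small outcome on both, but it does not show that the change has a real effect on either core, since each step lies within the scatter, and two cores in a single assay say nothing about how the change would behave on a third core.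

The compounds shown leave open whether a longer chain, with further 2-methoxyethoxy units, would still stay within the scatter on these two cores, and whether the picture would hold if an amine or a carboxylic acid stood at the chain end in place of the methoxy group. They also leave open whether the agreement between the two steps extends to any readout beyond this assay.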